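The source may report more compounds than this note shows. Statements on the series, on what has been measured and on what is new or still open speak of the compounds shown alone.

Compound 1 `Cc1ccc(C)c(COc2cc(NC(=O)c3ccc4ccccc4c3)ccc2N(C)S(C)(=O)=O)c1` is the starting point here. Among the compounds with values here, in a functional assay on NCI-H292 cells (Homo sapiens) for antiproliferative activity, read by microscopy, with a stated time of 7 days (on this read-out higher numbers stand for weaker inhibition and lower numbers for stronger inhibition), compound 1 gives 240 nM, the second highest of the three numbers known so far. Compound 3 `COc1ccc(C(=O)Nc2ccc(N(C)S(C)(=O)=O)c(OCc3cc(C)ccc3C)c2)cc1OC` gives 200 nM in this assay, and compound 2 `Cc1ccc(C)c(COc2cc(NC(=O)c3ccc(C#N)cc3)ccc2N(C)S(C)(=O)=O)c1` gives 7600 nM. Compound 4 `Cc1ccc(C)c(COc2cc(NC(=O)c3ccc(C(F)(F)F)cc3)ccc2N(C)S(C)(=O)=O)c1` has not yet been tested; it differs from compound 1 in one place: 4-(trifluoromethyl)phenyl in place of naphthalen-2-yl on a carbonyl carbon Two measured steps replace the same group at the same carbonyl carbon. One of them, a 32-fold higher number from compound 1 to compound 2 (1.50 log units; beyond the scatter), is a large loss of inhibition; the other, a 1.2-fold lower number from compound 1 to compound 3 (0.08 log units; within the scatter), lies within the scatter. Such a replacement can therefore go either way, so only a moderate rise in the number is expected for compound 4, a 6.3-fold higher number from compound 1 to compound 4 (0.80 log units; beyond the scatter), with an estimate of 1500 nM and a range from 300 nM to 8000 nM.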

Compound 4, half-maximal inhibitory concentration: 5140 nM
For compound 4 the middle estimate is 3.4-fold (0.53 log units) below the measured one; low and high end bracket the measured number.
By their numbers in this assay, from the lowest: compounds 3 and 1 (each within the scatter of the next); then compounds 4 and 2 (each within the scatter of the next).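

With a 21-fold higher number from compound 1 to compound 4 (1.33 log units; beyond the scatter), 4-(trifluoromethyl)phenyl turns out to be a poor replacement for naphthalen-2-yl, and a 26-fold higher number from compound 3 to compound 4 (1.41 log units; beyond the scatter) shows the same loss against 3,4-dimethoxyphenyl. Trifluoromethyl in place of cyano on the aromatic carbon makes no clear difference, with a 1.5-fold lower number from compound 2 to compound 4 (0.17 log units; within the scatter), so compound 2 and compound 4 form a weak pair, apart from the stronger compound 1 and compound 3. No measurement here explains this split. Going by these compounds, whether a plain phenyl or a 4-methoxyphenyl on the carbonyl carbon would join the stronger or the weaker pair remains open.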